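This account rests on a few compounds, and the source may have more. Where it says the series, first, only, none or still open, it means among the compounds named here.

Working notes on the series.

Compound 1 `CCN(c1ccc(C#N)c(Cl)c1)c1cc(-c2cccnc2)ccc1C` and compound 2 `CCN(c1cccc(-n2ccnc2)c1)c1ccc(C#N)c(Cl)c1` are the two members with numbers. In an ADME assay on L02 cells (Homo sapiens) for antiproliferative activity, read by CCK-8 assay, with a stated time of 6 days (a higher number here means a weaker inhibitor, a lower number a stronger inhibitor), compound 1 gives 12700 nM and compound 2 gives 23200 nM; both sit at the weak end of the range, and the gap between them is modest. Compound 3 `CCN(c1ccc(C#N)c(Cl)c1)c1cc(-n2cccn2)ccc1C` carries 1H-pyrazol-1-yl on the same core as compound 1, and in this assay compound 3 gives "not determined" (no result reported); it stands only as a structure, with no number to place it against compound 1 or compound 2.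

The step to compound 4 `CCN(c1ccc(C#N)c(Cl)c1)c1cc(-c2ccnn2C)ccc1C` is 1-methyl-1H-pyrazol-5-yl in place of 1H-pyrazol-1-yl on an aromatic carbon. Among the measured compounds shown here, with no measured pair to anchor this exchange, the expected step in this assay is small, in neither direction beyond the scatter, since every measured member of the series sits in the same weak region and the change leaves the rest of the molecule untouched.

For compound 4 the estimated value in this assay is 16000 nM, with a range from 6000 nM to 40000 nM.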

Compound 4, half-maximal inhibitory concentration: 6230 nM
Estimate against measurement, compound 4: 2.6-fold (0.41 log units) above; low and high end bracket the measured number.
By their numbers in this assay, from the lowest: compound 4; then compounds 1 and 2 (each within the scatter of the next).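

In this assay, among the compounds shown here, the place on the aromatic carbon, meta to a large group and para to a methyl group, proves responsive to exchange: 1-methyl-1H-pyrazol-5-yl in place of pyridin-3-yl gives a 2.0-fold lower number from compound 1 to compound 4 (0.31 log units; beyond the scatter) and is the first readable single change. The step is modest, but it shows that a five-membered aromatic ring with 2 hetero atoms can stand at this place and lower the number relative to the six-membered pyridin-3-yl of compound 1. No measurement on hand accounts for this step.

The step from compound 3 to compound 4 cannot be read, so 1H-pyrazol-1-yl and 1-methyl-1H-pyrazol-5-yl remain unseparated at this place. From the compounds shown here alone, whether an amine, a carboxylic acid or a longer chain here would move the number further stays open.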